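Para-substituent swap on the shared core: Vero cytotoxicity

The source may hold more compounds than are shown below. What is called first, only, known or untested is meant among the compounds shown, and "the series" means these compounds.

Measured compounds:
compound 1 `Fc1ccc(-c2nn3c(NC4CCCC4)cccc3c2-c2ccnc(NC3CCCC3)n2)cc1` — > 160000 nM
compound 2 `CC(C)Nc1ccn2nc(-c3ccc(F)cc3)c(-c3ccnc(NC4CCCC4)n3)c2c1` — > 40000 nM

In an ADME assay on Vero cells (Chlorocebus sabaeus) for cytotoxicity (a lower number here means that less compound is tolerated, a higher number that more compound is tolerated), compound 1 gives > 160000 nM, which is a limit of the assay and not a number; it sits at the limit of > 160000 nM in this assay, at which 1 of the 2 values shown sits. Compound 2 gives > 40000 nM, again a limit of the assay, at the limit of > 40000 nM in this assay, at which 1 of the 2 values shown sits. Within the data shown here, with two limits and no numbers, the two values show only that neither compound was toxic within the tested range; no order between them can be drawn.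

The step to compound 3 `COc1ccc(-c2nn3c(NC4CCCC4)cccc3c2-c2ccnc(NC3CCCC3)n2)cc1` changes the substituent on the phenyl of compound 1: methoxy in place of fluoro on an aromatic carbon, a methoxy in place of fluoro on an aromatic carbon, which on the wider reading turns 4-fluorophenyl into 4-methoxyphenyl. Among the measured compounds shown here, no measured pair shows this change. The expectation is that the step from compound 1 to compound 3 in this assay is an at least 1.0-fold lower number from compound 1 to compound 3 (0.02 log units; that floor lies within the scatter), that is, none beyond the scatter. Compound 3 is therefore expected to give about 150000 nM, between 40000 nM and 400000 nM, most likely again reported only as a limit.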

Compound 3, half-maximal cytotoxic concentration: > 100000 nM
Compound 3 ended at the assay's limit; the forecaster's own chance of this, stated with the estimate: 70%; the middle value lies beyond the limit too.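

Compound 1 and compound 3 both stand at limits in this assay, not at numbers, so the change from fluoro to methoxy gives no readable step between them. The compounds shown leave open at what concentration, if any, these compounds become toxic to the cells, and whether that concentration differs between them.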